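This account rests on a few compounds, and the source may have more. Where it says the series, first, only, none or still open, it means among the compounds named here.

In a functional assay on isolated protein for inhibition of Glucose-dependent insulinotropic receptor (Homo sapiens), read by HTRF and cAMP accumulation (a lower number here means that less compound is needed, a higher number that more compound is needed for the effect), compound 1 `Cc1nc(S(C)(=O)=O)ccc1Oc1ncnc(OC2CCN(C(=O)OC(C)(C)C(F)(F)F)CC2)c1F` gives 6.53 nM. Compound 2 `Cc1nc(S(C)(=O)=O)ccc1Oc1ncnc(OC2CCN(C(=O)SC(C)C)CC2)c1F` gives 6.8 nM, and compound 3 `Cc1nc(S(C)(=O)=O)ccc1Oc1ncnc(OC2CCN(C(=O)SC3CCC3)CC2)c1F` gives 8.51 nM. All three share one core and differ only in the group attached to the carbonyl carbon on the ring nitrogen. Those differences moved the numbers little: a 1.0-fold higher number from compound 1 to compound 2 (0.02 log units; within the scatter), a 1.3-fold higher number from compound 1 to compound 3 (0.12 log units; within the scatter) and a 1.3-fold higher number from compound 2 to compound 3 (0.10 log units; within the scatter). Of the three numbers, that of compound 3 is the highest, but its gaps to compounds 1 and 2 both lie within the scatter, so nothing separates them. Compound 4 `Cc1nc(S(C)(=O)=O)ccc1Oc1ncnc(OC2CCN(C(=O)C3CCCC3)CC2)c1F` changes the same place: cyclopentyl in place of cyclobutylsulfanyl on a carbonyl carbon. The earlier steps shown here swapped one group joined through oxygen or sulfur for another, whereas here the sulfur link is removed and the ring joins the carbonyl carbon directly. Among the compounds with values here, since every measured step at this position stayed within the scatter, the step from compound 3 to compound 4 is expected to be small, a 1.4-fold higher number from compound 3 to compound 4 (0.15 log units; within the scatter), with a wide range because no measured step removed the linking atom. Compound 4 is expected to give 12 nM in this assay, between 4 nM and 40 nM.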

Compound 4, half-maximal effective concentration: 72.8 nM
The estimate for compound 4 lay 6.1-fold (0.78 log units) below the measured number, outside the stated range (above it).
By their numbers in this assay, from the lowest: compounds 1, 2 and 3 (each within the scatter of the next); then compound 4.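

Until now, every group on this carbonyl carbon was joined through an oxygen or a sulfur, and exchanging them changed little. Joining a cyclopentyl ring directly to the carbonyl carbon is the first change here that clearly counts, giving an 8.6-fold higher number from compound 3 to compound 4 (0.93 log units; beyond the scatter) and an 11-fold higher number from compound 2 to compound 4 (1.03 log units; beyond the scatter) as well as an 11-fold higher number from compound 1 to compound 4 (1.05 log units; beyond the scatter) at this single position. Cyclobutylsulfanyl and cyclopentyl have the same heavy-atom count, so that count alone does not set the number, but no supporting data are available to explain the loss.

As far as these compounds go, it remains open whether the missing linking atom or the change of ring matters more, which a cyclopentylsulfanyl group on the same carbonyl carbon would help to separate. Also open, from the compounds shown here alone, is whether a nitrogen link, as in a cyclobutylamino group, would behave like the oxygen and sulfur links.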